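This account rests on a few compounds, and the source may have more. Where it says the series, first, only, none or still open, it means among the compounds named here.

The measured compounds in an ADME assay on MOLT-3 cells (Homo sapiens) for cytotoxicity, with a stated time of 7 days; a lower number here means that less compound is tolerated, a higher number that more compound is tolerated:

compound 1 `CCOc1nc(N)nc2c1ncn2/C=C1/CC1(CO)CO` – > 20000 nM, a limit of the assay
compound 2 `Nc1nc(OCc2ccccc2)c2ncn(/C=C3/CC3(CO)CO)c2n1` – > 20000 nM, a limit of the assay
compound 3 `CC(C)Nc1nc(N)nc2c1ncn2/C=C1/CC1(CO)CO` – "not determined" (no result reported), no result reported

Compound 2 stands only at a limit in this assay: its value of > 20000 nM is a limit, not a number. Going by the values given here, the one other value shown is also a limit, and the third entry carries no number at all, so nothing places compound 2 above or below its neighbours. Compound 4 `CCCCNc1nc(N)nc2c1ncn2/C=C1/CC1(CO)CO` has not yet been measured. It differs from compound 2 in one place: butylamino in place of benzyloxy on an aromatic carbon. Among the compounds with values here, the single measured step that touches this position, a step that the two limits leave unreadable from compound 1 to compound 2, sits between two limits and its size cannot be read. Within the data shown here, the only evidence available is the limit of > 20000 nM in this assay, at which 2 of the 3 values shown sit. Among the measured compounds shown here, no step therefore tells how large a move to expect in this assay, or in which direction. Compound 4 is expected to give about 30000 nM, with a range from 10000 nM to 100000 nM, most likely reported again as a limit. The expected step is a step that the limit leaves unreadable from compound 2 to compound 4.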

Compound 4, half-maximal cytotoxic concentration: > 20000 nM
Compound 4: a limit, no number (the forecaster's own chance of this, stated with the estimate: 80%); the middle value lies beyond the limit too.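

In this assay, going by these compounds alone, compound 1, compound 2 and compound 4 each give only a limit, not a number, so no step among them can be read: the limit of > 20000 nM in this assay, at which 3 of the 4 values shown sit. On these data alone, whether ethoxy, benzyloxy and butylamino differ at all in how much compound is tolerated stays open.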